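The source may report more compounds than this note shows. Statements on the series, on what has been measured and on what is new or still open speak of the compounds shown alone.

Measured so far in a functional assay, read by spectrophotometry, with a stated time of 3 min; on this read-out lower numbers stand for stronger inhibition and higher numbers for weaker inhibition:

- compound 1 `O=c1cc(/C=N\c2ccc(O)cc2)c2ccc(OCc3ccccc3)cc2o1` gives 64500 nM
- compound 2 `O=c1cc(/C=N\O)c2c(OCc3ccccc3)cc(OCc3ccccc3)cc2o1` gives 38700 nM
- compound 3 `Nc1ccccc1/N=C\c1cc(=O)oc2cc(OCc3ccccc3)cc(OCc3ccccc3)c12` gives 7530 nM

Compound 1 carries the highest number of the three, but compound 1 and compound 2 lie within the scatter of each other. Compound 3 stands lower than compound 1 by more than the scatter.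

The next step leads to compound 4 `Nc1ccccc1/N=C\c1cc(=O)oc2cc(OCc3ccccc3)ccc12`, which keeps the core of compound 1 and has 2-aminophenyl in place of 4-hydroxyphenyl on a double-bonded nitrogen.

Among the compounds with values here, only one measured step bears on this change: a 5.1-fold lower number from compound 2 to compound 3 (0.71 log units; beyond the scatter). There, 2-aminophenyl also enters on a double-bonded nitrogen, and the change in this assay is modest but beyond the scatter. The parallel is incomplete, since that step replaces hydroxy rather than 4-hydroxyphenyl and the core of compound 2 differs from the core of compound 1. Within the data shown here, no measured step shows the effect of removing 4-hydroxyphenyl.

A lower number is therefore expected, with a step of similar or somewhat smaller size. The expected change in this assay is a 4.0-fold lower number from compound 1 to compound 4 (0.61 log units; beyond the scatter). For compound 4 the estimated value is 16000 nM, with an expected range from 5000 nM to 50000 nM.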

Compound 4, half-maximal inhibitory concentration: 9250 nM
For compound 4 the middle estimate is 1.7-fold (0.24 log units) above the measured one; the measured number falls inside the stated range.
By their numbers in this assay, from the lowest: compounds 3 and 4 (each within the scatter of the next); then compounds 2 and 1 (each within the scatter of the next).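

With the core of compound 1 held fixed, 2-aminophenyl in place of 4-hydroxyphenyl on the double-bonded nitrogen gives in this assay a 7.0-fold lower number from compound 1 to compound 4 (0.84 log units; beyond the scatter), so the group on that nitrogen moves the number on its own, where the earlier step set 2-aminophenyl only against hydroxy and on a different core. With 2-aminophenyl kept, hydrogen in place of benzyloxy on an aromatic carbon gives a 1.2-fold higher number from compound 3 to compound 4 (0.09 log units; within the scatter), so in this pair that benzyloxy group makes no readable difference in this assay. Nothing at hand accounts for either step.

Open, going by these compounds, is whether the amine of 2-aminophenyl carries the step from compound 1 to compound 4 or the aromatic ring alone would do, a question that a plain phenyl group on the double-bonded nitrogen would settle. Also open, on these data alone, is what the benzyloxy group kept in compound 4 contributes, and whether a methoxy group in its place would read the same.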